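Branching of the unsaturated amide chain in a HepG2 series

The source may hold more compounds than are shown below. What is called first, only, known or untested is meant among the compounds shown, and "the series" means these compounds.

Compound 1 `CCC/C=C\C(=O)Nc1cc(Nc2nccc(-c3cn(C)c4ccccc34)n2)c(OC)cc1N(C)CCN(C)C`: 431 nM
Compound 2 `COc1cc(N(C)CCN(C)C)c(NC(=O)/C=C\C(C)C)cc1Nc1nc(C)cc(-c2cn(C)c3ccccc23)n1`: 3550 nM

Of the compounds shown here, two have been measured in a functional assay on HepG2 cells (Homo sapiens) for antiproliferative activity, read by MTT assay, with a stated time of 72 h; on this read-out higher numbers stand for weaker inhibition and lower numbers for stronger inhibition. Compound 1 gives 431 nM, while compound 2 gives 3550 nM, the highest of the two numbers; its gap to compound 1 lies beyond the scatter. Among the compounds with values here, the two differ in more than one place, so no single step between them can be read.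

Compound 3 `CCC/C=C\C(=O)Nc1cc(Nc2nc(C)cc(-c3cn(C)c4ccccc34)n2)c(OC)cc1N(C)CCN(C)C` has not yet been measured. It differs from compound 2 in one place only: propyl in place of isopropyl on a double-bonded chain carbon bound to a double-bonded chain carbon. The remaining parts, including the shared core, are unchanged.

Within the data shown here, with no measured step of this kind to lean on, the direction is uncertain. A modest move toward a lower number is expected, since compound 1 with 431 nM also carries the propyl chain, though it differs elsewhere too. Compound 3 is therefore estimated at 1500 nM, within 500 nM to 4500 nM, which means an expected step of a 2.4-fold lower number from compound 2 to compound 3 (0.37 log units; beyond the scatter).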

Compound 3, half-maximal inhibitory concentration: 365 nM
Compound 3: middle estimate off by 4.1-fold (0.61 log units), on the high side, outside the stated range (below it).
By their numbers in this assay, from the lowest: compounds 3 and 1 (each within the scatter of the next); then compound 2.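

In this assay, propyl in place of isopropyl on a double-bonded chain carbon bound to a double-bonded chain carbon gives a 9.7-fold lower number from compound 2 to compound 3 (0.99 log units; beyond the scatter), so how the same three carbons are joined in this chain clearly counts. Methyl in place of hydrogen on an aromatic carbon, with the propyl chain kept, gives a 1.2-fold lower number from compound 1 to compound 3 (0.07 log units; within the scatter), so no effect of that change can be claimed on this read-out. Of these two places, only the chain shows a step beyond the scatter, and nothing at hand gives a reason for that step.

The compounds shown leave open how a longer chain such as hexyl, or a chain ending in an amine, would fare at this place. They also leave open whether ethyl on the aromatic carbon would behave as methyl does.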